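The compounds below may be only part of what the source reports. "The series", "measured", "known", "first", "only" and "open" are said of these compounds alone.

Measured so far: compound 1 `O=C(NCc1cn(Cc2ccc(F)cc2)nn1)c1cn(-c2ccccc2)nc1-c1ccc(Cl)cc1` and compound 2 `COc1ccc(-c2nn(-c3ccccc3)cc2C(=O)NCc2cn(Cc3ccc(F)cc3)nn2)cc1`.

In a functional assay on HeLa cells (Homo sapiens) for antiproliferative activity, read by sulforhodamine B assay, with a stated time of 48 h (a higher number here means a weaker inhibitor of growth, a lower number a stronger inhibitor of growth), compound 1 gives 2800 nM. In this assay compound 2 gives 500 nM, the lowest of the two numbers. Within the data shown here, the only measured step, a 5.6-fold lower number from compound 1 to compound 2 (0.75 log units; beyond the scatter), concerns methoxy in place of chloro on an aromatic carbon, a different place from the one now changed.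

Compound 3 `COc1ccc(-c2nn(-c3ccccc3)cc2C(=O)NCc2cn(Cc3ccc(OC)c(OC)c3)nn2)cc1` differs from compound 2 by 3,4-dimethoxyphenyl in place of 4-fluorophenyl on a saturated chain carbon bound to an aromatic nitrogen. Among the measured compounds shown here, no measured step bears on this place, so no step beyond the scatter is expected in this assay, no change at the digits printed from compound 2 to compound 3 (within the scatter). Compound 3 is therefore estimated at 500 nM, range 150 nM to 1700 nM.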

Compound 3, concentration for 50% growth inhibition: 800 nM
For compound 3 the middle estimate is 1.6-fold (0.20 log units) below the measured one; the measured number falls inside the stated range.
By their numbers in this assay, from the lowest: compounds 2 and 3 (each within the scatter of the next); then compound 1.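

In this assay, among these compounds, the change of 4-fluorophenyl to 3,4-dimethoxyphenyl gives a 1.6-fold higher number from compound 2 to compound 3 (0.20 log units; within the scatter), the first reading at this place, so the larger group, which carries hydrogen-bond acceptors that 4-fluorophenyl lacks, leaves the number within the scatter. On this pair, the place on a saturated chain carbon bound to an aromatic nitrogen accepts this change without a step beyond the scatter. No measurement at hand explains this outcome.

Still open, from the compounds shown here alone, is whether an amine or a carboxylic acid on this ring, or a longer chain carrying it, would move the number beyond the scatter. The compounds shown also leave open whether 3,4-dimethoxyphenyl behaves alike with chloro in place of methoxy.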